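The source may report more compounds than this note shows. Statements on the series, on what has been measured and on what is new or still open speak of the compounds shown alone.

Within the data shown here, in an assay on isolated protein for displacement of a labelled ligand from metabotropic glutamate receptor 5 (Homo sapiens), with a stated time of 60 min, tested at 1 uM (a lower number here means less inhibition, a higher number more inhibition at the concentration tested (going by the name of the read-out)), compound 1 `CC1CCN(c2c(S(=O)(=O)c3cc(F)cc(F)c3)cnc3cc(Cl)ccc23)CC1` gives 94%, the higher of the two numbers known so far. Compound 2 `CC1CCN(c2c(S(=O)(=O)c3cccc(F)c3)cnc3ccc(Cl)cc23)CC1` gives 58% in this assay, a gap beyond the usual scatter; these two compounds differ in more than one place, so only the numbers themselves can be compared. Compound 3 `CC1CCN(c2c(S(=O)(=O)c3ccc(F)c(Cl)c3)cnc3cc(Cl)ccc23)CC1` differs from compound 1 by 3-chloro-4-fluorophenyl in place of 3,5-difluorophenyl on a sulfonyl sulfur, on the sulfonyl sulfur. Among the measured compounds shown here, no single-change step has been measured, so a modest downward step, or none beyond the scatter, is expected a number 9 percentage points lower from compound 1 to compound 3 (within the scatter). Compound 3 is expected to give about 85% in this assay, within a range from 65% to 98%.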

Compound 3, a percentage reported as inhibition, at one concentration (the size of the read-out at that concentration, not a potency): 94%
Beside the measured number, compound 3's estimate is 9 percentage points below it; the range from low to high includes it.
By their numbers in this assay, from the lowest: compound 2; then compounds 1 and 3 (each within the scatter of the next).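

On the sulfonyl sulfur, 3-chloro-4-fluorophenyl in place of 3,5-difluorophenyl gives no change at the digits printed from compound 1 to compound 3 (within the scatter) in this assay and so the number stays level across this change of substitution pattern on the phenyl ring, including the entry of a chlorine. Compound 1 and compound 3 therefore cannot be told apart in this read-out at the single concentration tested. No information is available to explain this result. Going by these compounds, whether a pyridyl ring or a cyclohexyl group on the sulfonyl sulfur would keep this level of inhibition remains open. So does whether compound 1 and compound 3 would separate at a lower concentration.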